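Acetyl on the Amide Nitrogen: Cytotoxicity Expected to Stay Low

A few compounds are considered here, and "the series" means these few. Any claim that something is new, unique, unknown or untested is made for them only; others in the source may bear on it.

compound 1 `O=C(NCc1ccco1)c1ccc(CN2C(=O)c3ccccc3S2(=O)=O)cc1`: > 100000 nM
compound 2 `O=C(NCc1ccco1)c1ccc(CN2C(=O)c3ccccc3C2=O)cc1`: > 100000 nM

Of the compounds shown here, two have been tested in an ADME assay on RAW264.7 cells (Mus musculus) for cytotoxicity, read by WST assay; a lower number here means that less compound is tolerated, a higher number that more compound is tolerated. For compound 1 the figure > 100000 nM is a limit of the assay rather than a measured number. Compound 2 likewise gives > 100000 nM, again a limit. So neither compound stands at a known value; both sit at the limit of > 100000 nM in this assay, at which 2 of the 2 values shown sit, and all that can be said of the pair is that the cells tolerated each compound up to that boundary.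

Compound 3 `CC(=O)N(Cc1ccco1)C(=O)c1ccc(CN2C(=O)c3ccccc3S2(=O)=O)cc1` is the next compound to be tested. It differs from compound 1 by acetyl in place of hydrogen on an amide-type nitrogen, which is acetyl in place of hydrogen on an amide-type nitrogen. Among the compounds with values here, no step between measured compounds is available to guide this change. The expectation is a step of no size beyond the usual scatter, a step that the limit leaves unreadable from compound 1 to compound 3. On that basis compound 3 is estimated to fall around 150000 nM, between 60000 nM and 400000 nM, and the assay is expected most likely to report only a limit once more.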

Compound 3, concentration lethal to 50% of the cells: > 100000 nM
Compound 3: no number, only a limit (the forecaster's own chance of this, stated with the estimate: 80%); the middle value lies beyond the limit too.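

In this assay, within the data shown here, compound 3, like compound 1, gives only a limit and not a number, so no step from compound 1 to compound 3 can be read: the limit of > 100000 nM in this assay, at which 3 of the 3 values shown sit.

The compounds shown leave open at what concentration each would harm the cells, and whether acetyl in place of hydrogen on the amide-type nitrogen changes that concentration.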